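Replacing the 4-cyclopropylpiperazin-1-yl group of compound 2

The source may hold more compounds than are shown below. What is called first, only, known or untested is meant among the compounds shown, and "the series" means these compounds.

In an ADME assay on CHO cells (Cricetulus griseus) for cytotoxicity, read by MTT assay (on this read-out lower numbers stand for higher toxicity in this test and higher numbers for lower toxicity in this test), compound 1 `O=C(c1ccnc(Nc2nc3cnc(Nc4ccc(F)c(C(F)(F)F)c4)cc3[nH]2)c1)N1CCN(C2CC2)CC1` gives 30000 nM. Compound 2 `O=C(c1ccnc(Nc2nc3cnc(Nc4ccc(F)c(F)c4)cc3[nH]2)c1)N1CCN(C2CC2)CC1` gives > 50000 nM, which is a limit of the assay and not a number. Compound 3 `C[C@@H]1CN(C(=O)c2ccnc(Nc3nc4cnc(Nc5ccc(F)c(F)c5)cc4[nH]3)c2)C[C@H](C)O1` carries 2,6-dimethylmorpholin-4-yl in place of 4-cyclopropylpiperazin-1-yl on a carbonyl carbon. Among the compounds with values here, the only measured step, an at least 1.6-fold higher number from compound 1 to compound 2 (0.22 log units; that floor lies within the scatter), puts fluoro in place of trifluoromethyl on an aromatic carbon, a different change at a different place. Within the data shown here, with only that step to go on, no change beyond the scatter is expected. The expected step is an at least 1.1-fold lower number from compound 2 to compound 3 (0.04 log units; that floor lies within the scatter). For compound 3 the estimated value is 45000 nM, with an expected range from 15000 nM to 100000 nM.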

Compound 3, half-maximal cytotoxic concentration in the CHO assay: > 50000 nM
Compound 3: no number, only a limit (the forecaster's own chance of this, stated with the estimate: 55%); middle value at least 1.1-fold (0.04 log units) from the limit.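

In a physicochemical assay for solubility, read by HPLC, using the shake flask method, in phosphate buffer, measured as kinetic solubility, with a stated time of 20 h, at pH 6.5 (on this read-out higher numbers stand for higher solubility and lower numbers for lower solubility), compound 2 gives < 5000 nM, which is a limit of the assay and not a number. In the physicochemical assay compound 3 gives < 5000 nM, which is also a limit of the assay and not a number. Neither the CHO assay nor the physicochemical assay yields a readable step between compound 2 and compound 3, as both compounds give only assay limits there, not numbers. From the compounds shown here alone, whether, and how far, the two compounds differ in either read-out remains open.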